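Azetidinylmethoxy pyridines: bromo to methyl exchange

The source may report more compounds than this note shows. Statements on the series, on what has been measured and on what is new or still open speak of the compounds shown alone.

Measured so far:
compound 1 `Fc1ccc(OC[C@@H]2CCN2)cn1` — 0.057 nM
compound 2 `Brc1cncc(OC[C@@H]2CCN2)c1` — 0.18 nM

In an assay on brain for binding affinity to Neuronal acetylcholine receptor; alpha4/beta2 (Rattus norvegicus), read by radioligand binding (on this read-out lower numbers stand for stronger inhibition and higher numbers for weaker inhibition), compound 2 gives 0.18 nM, the higher of the two numbers; compound 1 gives 0.057 nM, a gap beyond the scatter. Compound 3 `Cc1cncc(OC[C@@H]2CCN2)c1` differs from compound 2 by methyl in place of bromo on an aromatic carbon. Within the data shown here, no measured pair shows this exchange, so the size of the step is open; a step near or slightly above the scatter toward a higher number is expected, as a 1.4-fold higher number from compound 2 to compound 3 (0.14 log units; within the scatter). Compound 3 is estimated at 0.25 nM in this assay, within 0.08 nM to 0.8 nM.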

Compound 3, inhibition constant: 0.047 nM
For compound 3 the middle estimate is 5.3-fold (0.73 log units) above the measured one; the measured number lies below the stated range.
By their numbers in this assay, from the lowest: compounds 3 and 1 (each within the scatter of the next); then compound 2.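

In this assay, methyl in place of bromo on this aromatic carbon, two atoms from the ring nitrogen, gives a 3.8-fold lower number from compound 2 to compound 3 (0.58 log units; beyond the scatter), so bromo is not required here for a subnanomolar number. Both groups count one heavy atom, yet the number moves beyond the scatter, so this position responds to the identity of the group and not only to the heavy-atom count. Nothing available accounts for the step. Still open, going by these compounds, is whether a longer chain such as ethyl, an amine or a carboxylic acid on this carbon would keep the number of compound 3 .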